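From Compound 3 to Compound 4: Adding a Trifluoromethyl

This account rests on a few compounds, and the source may have more. Where it says the series, first, only, none or still open, it means among the compounds named here.

In a functional assay on SMMC-7721 cells (Homo sapiens) for cytotoxicity, read by MTT assay, with a stated time of 24 h (on this read-out higher numbers stand for weaker inhibition and lower numbers for stronger inhibition), three compounds sharing one core have been measured, and they differ only in the group on an amine nitrogen in a ring. Compound 1 `CN1C/C(=C\c2cccnc2)C(=O)/C(=C/c2ccccc2C(F)(F)F)C1`, with methyl there, gives 3900 nM. Compound 2 `O=C1/C(=C/c2cccnc2)CNC/C1=C\c1ccccc1C(F)(F)F`, with hydrogen there, gives 5100 nM, and a 1.3-fold higher number from compound 1 to compound 2 (0.12 log units; within the scatter) separates the two. Compound 3 `O=C1/C(=C/c2cccnc2)CN(S(=O)(=O)c2ccccc2)C/C1=C\c1ccccc1C(F)(F)F`, with phenylsulfonyl there, gives 10900 nM, the highest number of the three and so the weakest inhibition.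

Compound 4 `O=C1/C(=C/c2cccnc2)CN(S(=O)(=O)c2ccc(C(F)(F)F)cc2)C/C1=C\c1ccccc1C(F)(F)F` differs from compound 3 in one place: trifluoromethyl in place of hydrogen on an aromatic carbon. This is trifluoromethyl in place of hydrogen on an aromatic carbon, which turns phenyl into 4-(trifluoromethyl)phenyl. Among the measured compounds shown here, no measured step changes this aromatic ring, so the evidence is only indirect. The closest guides are a 2.8-fold higher number from compound 1 to compound 3 (0.45 log units; beyond the scatter) and a 2.1-fold higher number from compound 2 to compound 3 (0.33 log units; beyond the scatter), both modest even though a whole phenylsulfonyl group enters in each. A single substitution on that group is therefore not expected to move the number much in this assay. The expected change is a 1.1-fold lower number from compound 3 to compound 4 (0.06 log units; within the scatter), a small drop that would stay within the scatter. For compound 4 the estimated value is 9500 nM, with an expected range from 4500 nM to 20000 nM.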

Compound 4, half-maximal inhibitory concentration: 1730 nM
The estimate for compound 4 lay 5.5-fold (0.74 log units) above the measured number; the measured number lies below the stated range.
By their numbers in this assay, from the lowest: compound 4; then compounds 1 and 2 (each within the scatter of the next); then compound 3.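

In this assay, among the compounds shown here, the earlier compounds varied only the group on the ring nitrogen, and phenylsulfonyl gave the highest number of the three; a 6.3-fold lower number from compound 3 to compound 4 (0.80 log units; beyond the scatter) shows that the ring of that group, at the carbon para to a large group, is a place where a small change matters. This step, which adds only 4 heavy atoms, is larger in size than a 2.1-fold higher number from compound 2 to compound 3 (0.33 log units; beyond the scatter), which brought in the whole phenylsulfonyl group, and it runs in the opposite direction, so that compound 4 now has the lowest number of the four and a sulfonyl-bearing compound no longer sits at the weak end. Nothing measured here accounts for this drop, so its cause remains unknown.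

Whether the drop belongs to trifluoromethyl in particular stays open: a methoxy, a nitrile or a single fluorine in the same place could lower the number just as much, or not at all, and the compounds shown cannot tell these cases apart. Also open, going by these compounds, is whether the same step would lower the number on the compounds with a smaller group on the ring nitrogen, or in other cell lines.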